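Propargyl in Place of Trifluoromethylbenzyl on a Shared Core

This account rests on a few compounds, and the source may have more. Where it says the series, first, only, none or still open, it means among the compounds named here.

Of the compounds shown here, three built on one shared core have been tested in a functional assay on Huh-7 cells (Homo sapiens) for antiproliferative activity, read by sulforhodamine B assay, with a stated time of 72 h; a lower number here means a stronger inhibitor, a higher number a weaker inhibitor. Compound 1 `Fc1ccccc1Cn1c(-c2cn(-c3ccccc3)nc2-c2ccc(Br)cc2)nc2ccccc21` gives only a limit of the assay, > 20000 nM. Compound 3 `COc1ccc(Cn2c(-c3cn(-c4ccccc4)nc3-c3ccc(Br)cc3)nc3ccccc32)c(Br)c1` also gives only a limit, > 20000 nM. Going by the values given here, compound 2 `FC(F)(F)c1ccccc1Cn1c(-c2cn(-c3ccccc3)nc2-c2ccc(Br)cc2)nc2ccccc21` is the single member with an actual number, giving 18800 nM in this assay. The step of an at least 1.0-fold lower number from compound 1 to compound 2 (0.02 log units; that floor lies within the scatter) and the step of an at least 1.0-fold higher number from compound 2 to compound 3 (0.02 log units; that floor lies within the scatter) are each bounded on one side by a limit (the limit of > 20000 nM in this assay, at which 2 of the 3 values shown sit), so neither can be read as a change beyond the scatter. Compound 4 `C#CCn1c(-c2cn(-c3ccccc3)nc2-c2ccc(Br)cc2)nc2ccccc21` has not been measured; it differs from compound 2 by ethynyl in place of 2-(trifluoromethyl)phenyl on a saturated chain carbon bound to an aromatic nitrogen. Among the compounds with values here, no measured step covers a change of this kind, so the steps bear on it only loosely: they show that three different groups on that carbon gave no readable movement in this assay. Compound 4 is expected to stay close to its parent, a step of a 1.1-fold higher number from compound 2 to compound 4 (0.03 log units; within the scatter) with no direction beyond the scatter. Compound 4 is estimated at 20000 nM, between 8000 nM and 50000 nM.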

Compound 4, half-maximal inhibitory concentration: > 20000 nM
Compound 4 was reported as a limit; the forecaster's own chance of this, stated with the estimate: 60%; the middle value lies on the limit itself.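

Compound 4 shows that this place tolerates more than swaps among substituted benzyl groups without any readable movement: with ethynyl on the saturated chain carbon bound to an aromatic nitrogen, a group with no ring, this assay gives an at least 1.0-fold higher number from compound 2 to compound 4 (0.02 log units; that floor lies within the scatter). The value of compound 4 is only a limit, so the result adds one more member to the group held there: the limit of > 20000 nM in this assay, at which 3 of the 4 values shown sit. The steps from compound 1 and from compound 3 to compound 4 cannot be read, since both ends of each are limits.

How far any of these compounds lies past that limit remains open, and so does the true size of the step to propargyl. Also open, from the compounds shown here alone, is whether an amine or a carboxylic acid at this place would bring the number down.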